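This account rests on a few compounds, and the source may have more. Where it says the series, first, only, none or still open, it means among the compounds named here.

Compound 2 `CCO/N=C(\CCN1CCN(c2ncccc2C#N)CC1)c1ccccc1` carries a 3-cyanopyridin-2-yl group on an amine nitrogen in a ring, where compound 1 `CCO/N=C(\CCN1CCN(c2ccccc2)CC1)c1ccccc1` carries a phenyl group. In a functional assay on HEK293 cells with D(4) dopamine receptor (Homo sapiens) as the target, read by FLIPR (a lower number here means a smaller maximal response, a higher number a larger maximal response), compound 1 gives 80%, and in this assay compound 2 gives 64%. Among the measured compounds shown here, that single exchange produced the step of a number 16 percentage points lower from compound 1 to compound 2 (beyond the scatter), so compound 2 stands as the lower of the two values known so far.

Compound 3 `CCO/N=C(\CCN1CCN(c2ncccn2)CC1)c1ccccc1` differs from compound 2 in one place: pyrimidin-2-yl in place of 3-cyanopyridin-2-yl on an amine nitrogen in a ring. For the measured compounds named here, the only measured step, from phenyl to 3-cyanopyridin-2-yl, moved the maximal response down by a modest amount; no measured pair shows what pyrimidin-2-yl does on this amine nitrogen, so the step from compound 2 to compound 3 has no direct precedent. Going by the values given here, since the one known exchange at this position stayed modest, the author expects the change from compound 2 to compound 3 to be a number 6 percentage points higher from compound 2 to compound 3 (within the scatter), most likely within or only a little beyond the scatter. The maximal response of compound 3 in this assay is therefore estimated at 70%, with a range from 50% to 88%.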

Compound 3, largest response reached (reported as efficacy), in percent of the reference or control that the assay uses: 26%
Compound 3: middle estimate off by 44 percentage points, on the high side, outside the stated range (below it).
By their numbers in this assay, from the lowest: compound 3; then compound 2; then compound 1.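

Among the compounds shown here, at this position, on an amine nitrogen in a ring, the choice of aromatic group can move the maximal response much further than the one earlier exchange indicated. In this assay, for the compounds shown here, pyrimidin-2-yl gives a number 38 percentage points lower from compound 2 to compound 3 (beyond the scatter) and a number 54 percentage points lower from compound 1 to compound 3 (beyond the scatter), both large steps, whereas the only step known before, a number 16 percentage points lower from compound 1 to compound 2 (beyond the scatter), was modest. The group that leaves and the group that enters have the same counts of hydrogen-bond donors and acceptors, so those counts do not separate them, and nothing available accounts for the drop.

Compound 2 and compound 3 differ both in the number of hetero atoms in the ring and in the nitrile, so these compounds cannot show which of the two goes with the lower response; a plain pyridin-2-yl group on the same amine nitrogen would separate them. As far as these compounds go, it also remains open how a pyrimidin-2-yl group carrying a nitrile, or one carrying a methoxy group, would read out at this position.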